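The source may hold more compounds than are shown below. What is called first, only, known or untested is meant among the compounds shown, and "the series" means these compounds.

Measured so far in a functional assay on A549 cells (Homo sapiens) for antiproliferative activity, read by MTT assay, with a stated time of 72 h; a higher number here means a weaker inhibitor, a lower number a stronger inhibitor:
compound 1 `CNC(=O)c1cc(Oc2ccc(NC(=O)c3cc4cccnc4n(-c4ccccc4F)c3=O)cc2)ccn1` — 610 nM
compound 2 `CCNC(=O)c1cc(Oc2ccc(NC(=O)c3cc4cccnc4n(-c4ccccc4F)c3=O)cc2)ccn1` — 490 nM
compound 3 `CCNC(=O)c1cc(Oc2ccc(NC(=O)c3cc4cccnc4n(-c4ccc(F)cc4)c3=O)cc2)ccn1` — 120 nM

Compound 2 stands second highest of the three numbers; compound 1 is nearest, with a 1.2-fold lower number from compound 1 to compound 2 (0.10 log units; within the scatter) between them, while compound 3 sits furthest, with a 4.1-fold lower number from compound 2 to compound 3 (0.61 log units; beyond the scatter). Compound 4 `CCCNC(=O)c1cc(Oc2ccc(NC(=O)c3cc4cccnc4n(-c4ccccc4F)c3=O)cc2)ccn1` is not yet measured. It differs from compound 2 by methyl in place of hydrogen on a saturated chain carbon, two bonds along the chain from an amide-type nitrogen. Within the data shown here, only one measured step bears on this change, the chain lengthening a 1.2-fold lower number from compound 1 to compound 2 (0.10 log units; within the scatter), which stayed within the scatter. The other step, a 4.1-fold lower number from compound 2 to compound 3 (0.61 log units; beyond the scatter), concerns the fluorophenyl on the aromatic nitrogen, not the chain, and says nothing here. The added methyl is therefore expected to give no step beyond the scatter in this assay, a 1.1-fold lower number from compound 2 to compound 4 (0.04 log units; within the scatter). Compound 4 is estimated at 450 nM, range 200 nM to 1000 nM.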

Compound 4, half-maximal inhibitory concentration: 150 nM
For compound 4 the middle estimate is 3.0-fold (0.48 log units) above the measured one; the whole stated range lies above it.
By their numbers in this assay, from the lowest: compounds 3 and 4 (each within the scatter of the next); then compounds 2 and 1 (each within the scatter of the next).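

In this assay this position is shown to respond to chain length: ethyl to propyl gives a 3.3-fold lower number from compound 2 to compound 4 (0.51 log units; beyond the scatter) in the measured series. The wider change from methyl to propyl gives a 4.1-fold lower number from compound 1 to compound 4 (0.61 log units; beyond the scatter) and also lies beyond the scatter. Methyl to ethyl alone had stayed within it, so the response along this chain is uneven, and the step appears only with the methyl on the saturated chain carbon two bonds along from the amide-type nitrogen. No measured evidence accounts for this step.

From the compounds shown here alone, whether a butyl chain or an isopropyl group continues this response remains open. So does whether propyl gives a similar step alongside 4-fluorophenyl on the aromatic nitrogen.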